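Series notes: exchanging the aryl ring of compound 2

A few compounds are considered here, and "the series" means these few. Any claim that something is new, unique, unknown or untested is made for them only; others in the source may bear on it.

Compound 2 `CC1=CC[C@H](C(C)(C)NC(=S)N/N=C/c2cccc(Cl)c2)CC1` gives 9200 nM in a functional assay on 786-0 cells (Homo sapiens) for inhibition, read by sulforhodamine B assay, with a stated time of 48 h (on this read-out higher numbers stand for weaker inhibition of growth and lower numbers for stronger inhibition of growth), and holds the lowest number of the two measured. Among the compounds with values here, compound 1 `CC1=CC[C@H](C(C)(C)NC(=S)N/N=C/c2ccccc2Cl)CC1` gives 85500 nM in this assay; the change a 9.3-fold lower number from compound 1 to compound 2 (0.97 log units; beyond the scatter) is the only step recorded. Compound 3 `CC1=CC[C@H](C(C)(C)NC(=S)N/N=C/c2cccs2)CC1` differs from compound 2 by thiophen-2-yl in place of 3-chlorophenyl on a carbon with a double bond to nitrogen. Within the data shown here, no measured step concerns exchange of the aromatic ring itself; the one step seen covers only chlorine placement, so it bears on this change at best indirectly. A step of the order of a 2.2-fold higher number from compound 2 to compound 3 (0.34 log units; beyond the scatter) is expected, toward a higher number, with wide uncertainty. Compound 3 is estimated at 20000 nM, range 6000 nM to 70000 nM.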

Compound 3, concentration for 50% growth inhibition: 11500 nM
For compound 3 the middle estimate is 1.7-fold (0.24 log units) above the measured one; low and high end bracket the measured number.
By their numbers in this assay, from the lowest: compounds 2 and 3 (each within the scatter of the next); then compound 1.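

In this assay the aromatic ring on the carbon with a double bond to nitrogen can be exchanged with no change beyond the scatter (a 1.3-fold higher number from compound 2 to compound 3 (0.10 log units; within the scatter)). Thiophen-2-yl also stands clear of 2-chlorophenyl (a 7.4-fold lower number from compound 1 to compound 3 (0.87 log units; beyond the scatter)), so among these compounds chlorine is not required to reach the level of compound 2. Nothing at hand explains either step.

On these data alone, whether a pyridin-3-yl ring, or a phenyl ring carrying an amine or a carboxylic acid, would hold this level remains open. So does whether any exchange here can go lower than compound 2 and compound 3.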